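Chloro for bromo on the shorter-chain compound 4

The source may report more compounds than this note shows. Statements on the series, on what has been measured and on what is new or still open speak of the compounds shown alone.

Measured so far:
compound 1, `O=C1C(=O)N(CCCCCn2cc(COc3cc(=O)oc4ccccc34)nn2)c2ccc(Cl)cc21`, which in a functional assay on COLO 205 cells (Homo sapiens) for inhibition, read by sulforhodamine B assay, with a stated time of 48 h, tested at 50 uM (a higher number here means more inhibition of growth at the concentration tested, a lower number less inhibition of growth), gives 48%
compound 2, `O=C1C(=O)N(CCCCCn2cc(COc3cc(=O)oc4ccccc34)nn2)c2ccc(Br)cc21`, which in this assay gives 39%
compound 3, `O=C1C(=O)N(CCCn2cc(COc3cc(=O)oc4ccccc34)nn2)c2ccc(Br)cc21`, which in this assay gives 61%

Compound 1 and compound 2 share one core and differ only in the halogen: chloro in place of bromo on an aromatic carbon. In this assay this gives a number 9 percentage points higher from compound 2 to compound 1 (within the scatter), so the two halogens cannot be told apart on this pair.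

Compound 3 carries the bromo but a different chain; the difference between its core and the core of compound 2 is not broken down here. Its value in this assay is the highest of the three, beyond the scatter against both compound 1 and compound 2, with compound 1 the nearer of the two.

Compound 4, `O=C1C(=O)N(CCCn2cc(COc3cc(=O)oc4ccccc34)nn2)c2ccc(Cl)cc21`, has not been measured in this assay. It relates to compound 3 as compound 1 relates to compound 2: chloro in place of bromo on an aromatic carbon, at the same place in the same words, so this is the same change. Going by the values given here, the only measured instance of it, a number 9 percentage points higher from compound 2 to compound 1 (within the scatter), is within the scatter. On that basis a step of about a number 3 percentage points higher from compound 3 to compound 4 (within the scatter) is expected, resting on compound 2 to compound 1 and on compound 3 at 61%. Compound 4 is therefore estimated at 64%, between 50% and 78%, with the chain of compound 3 kept and no real gain or loss expected from the halogen.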

Compound 4, percent growth inhibition at one concentration: 67%
Compound 4: middle estimate off by 3 percentage points, on the low side; the range from low to high includes it.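

In this assay, chloro in place of bromo on an aromatic carbon, now read on the core of compound 3, gives a number 6 percentage points higher from compound 3 to compound 4 (within the scatter). Set beside the earlier step, the change carries from one core to the other without a difference that can be detected: the same change on two cores in this assay, a number 9 percentage points higher (within the scatter) from compound 2 to compound 1 and a number 6 percentage points higher (within the scatter) from compound 3 to compound 4, 3 percentage points apart, within the scatter of two such steps. Going by these compounds alone, this shows only that the swap between these two halogens makes no real difference on either core at the single concentration tested; it does not separate chloro from bromo, and two cores are too few to show that the same holds across the series.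

Still open, on these data alone, is how other groups on this aromatic carbon, such as fluoro, methoxy, trifluoromethyl or a nitrile, would compare with the two halogens, and how the parent compound with hydrogen there would read. Also open is whether the swap stays as small on a longer chain than any shown here, or on a chain carrying an amine or a carboxylic acid.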